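A few compounds are considered here, and "the series" means these few. Any claim that something is new, unique, unknown or untested is made for them only; others in the source may bear on it.

Series notes. In an assay on microsomes from Testis (strain Sprague-Dawley) for inhibition of steroid 17-alpha-hydroxylase/17,20 lyase (Rattus norvegicus) (a higher number here means a weaker inhibitor, a lower number a stronger inhibitor), compound 3 `CCNC(=O)c1ccc2cc(C(O)(c3c[nH]cn3)C(C)C)ccc2c1` gives 11 nM, the lowest of the two numbers shown; compound 1 `COC(=O)c1ccc2cc(C(O)(c3c[nH]cn3)C(C)C)ccc2c1` gives 43 nM, with a 3.9-fold lower number from compound 1 to compound 3 (0.59 log units; beyond the scatter). Compound 2 `CC(C)C(O)(c1ccc2cc(C(N)=O)ccc2c1)c1c[nH]cn1` sits at a limit of this assay, < 10 nM. The steps of an at least 4.3-fold lower number from compound 1 to compound 2 (0.63 log units; beyond the scatter) and an at least 1.1-fold higher number from compound 2 to compound 3 (0.04 log units; that floor lies within the scatter) touch the same carbonyl group, the second within the scatter, and the limit of < 10 nM in this assay, at which 1 of the 3 values shown sits, caps what compound 2 can show. Compound 4 `CNC(=O)Nc1ccc2cc(C(O)(c3c[nH]cn3)C(C)C)ccc2c1` differs from compound 3 by (methylcarbamoyl)amino in place of ethylcarbamoyl on an aromatic carbon. Among the compounds with values here, no measured step makes a change of the urea type; the amide steps all stay small or within the scatter, so an expected step in this assay is at most the scatter, a 1.8-fold higher number from compound 3 to compound 4 (0.26 log units; within the scatter). Compound 4 is estimated at 20 nM, within 6 nM to 60 nM.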

Compound 4, half-maximal inhibitory concentration: 11 nM
Beside the measured number, compound 4's estimate is 1.8-fold (0.26 log units) above it, within the range that was stated.
By their numbers in this assay, from the lowest: compounds 3 and 4 (each within the scatter of the next); then compound 1. At a limit, below all of these: compound 2.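

In this assay, (methylcarbamoyl)amino in place of ethylcarbamoyl on an aromatic carbon gives no change at the digits printed from compound 3 to compound 4 (within the scatter), so the group can join the core through nitrogen as well as through carbonyl. Replacing methoxycarbonyl with this urea group gives a 3.9-fold lower number from compound 1 to compound 4 (0.59 log units; beyond the scatter), which places it with the ethyl amide rather than the ester. Compound 2 stands at a limit: the limit of < 10 nM in this assay, at which 1 of the 4 values shown sits. The step to the urea, an at least 1.1-fold higher number from compound 2 to compound 4 (0.04 log units; that floor lies within the scatter), therefore cannot be read as a measured difference.

Going by these compounds, a primary amine or a carboxylic acid at this aromatic carbon remains open, as does a longer chain on the urea nitrogen.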